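Aryl-triazole diaryl ureas: step from compound 3 to compound 4

The source may hold more compounds than are shown below. What is called first, only, known or untested is meant among the compounds shown, and "the series" means these compounds.

Measured so far in a functional assay on HepG2 cells (Homo sapiens) for inhibition, read by MTT assay, with a stated time of 72 h; on this read-out lower numbers stand for stronger inhibition and higher numbers for weaker inhibition:
compound 1 `CC(C)c1ccccc1-n1cc(COc2cccc(NC(=O)Nc3ccc(Cl)c(C(F)(F)F)c3)c2)nn1` gives 1900 nM
compound 2 `CC(C)c1cccc(-n2cc(COc3cccc(NC(=O)Nc4ccc(Cl)c(C(F)(F)F)c4)c3)nn2)c1` gives 3250 nM
compound 3 `O=C(Nc1cccc(OCc2cn(-c3cccc(F)c3)nn2)c1)Nc1ccc(Cl)c(C(F)(F)F)c1` gives 2120 nM

Compound 3 sits second highest of the three numbers. Its nearest neighbour is compound 1 (a 1.1-fold higher number from compound 1 to compound 3 (0.05 log units; within the scatter)) and its furthest is compound 2 (a 1.5-fold lower number from compound 2 to compound 3 (0.19 log units; within the scatter)); both steps lie within the scatter, so the three compounds cannot be ordered in this assay.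

Compound 4 `O=C(Nc1cccc(OCc2cn(-c3cccc(I)c3)nn2)c1)Nc1ccc(Cl)c(C(F)(F)F)c1` is the next member. Relative to compound 3 it carries iodo in place of fluoro on an aromatic carbon.

The steps measured so far concern the same aryl group on the aromatic nitrogen: a 1.7-fold higher number from compound 1 to compound 2 (0.23 log units; within the scatter), a 1.1-fold higher number from compound 1 to compound 3 (0.05 log units; within the scatter) and a 1.5-fold lower number from compound 2 to compound 3 (0.19 log units; within the scatter). Within the data shown here, none of them exchanges one halogen for another, and the only step at the aromatic carbon in question, fluoro in place of isopropyl, stayed within the scatter. With three substituents of quite different size all giving numbers within the scatter of one another, no direction can be read off for iodo, and the step of a 1.0-fold lower number from compound 3 to compound 4 (0.00 log units; within the scatter) is expected to stay within the scatter too.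

Compound 4 is therefore estimated at 2100 nM, with a range from 900 nM to 5000 nM.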

Compound 4, half-maximal inhibitory concentration: 4780 nM
Compound 4: the middle estimate sits 2.3-fold (0.36 log units) below what was measured, and the stated range covers the measured number.
By their numbers in this assay, from the lowest: compounds 1, 3, 2 and 4 (each within the scatter of the next, the first and the last beyond it).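

In this assay, fluoro and iodo on this aromatic carbon can be told apart (a 2.3-fold higher number from compound 3 to compound 4 (0.35 log units; beyond the scatter)), a modest step but one beyond the scatter, whereas every step among compounds 1, 2 and 3 stayed within it. The position is therefore not indifferent to the substituent, although the picture is not a simple ranking: isopropyl cannot be separated from iodo (a 1.5-fold higher number from compound 2 to compound 4 (0.17 log units; within the scatter)) or from fluoro, while the change from 2-isopropylphenyl to 3-iodophenyl on the aromatic nitrogen also passes the scatter (a 2.5-fold higher number from compound 1 to compound 4 (0.40 log units; beyond the scatter)) and remains modest. No available measurement accounts for these steps.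

On these data alone, it remains open whether bromo or chloro on the same carbon would group with fluoro or with iodo, and so whether the step follows the halogen series at all. A nitrile, a methoxy group or an amine at this carbon would show whether numbers beyond the scatter are confined to iodo or also arise with non-halogen groups.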